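Swapping Methyl for Cyclohexyl on the Ring Nitrogen

A few compounds are considered here, and "the series" means these few. Any claim that something is new, unique, unknown or untested is made for them only; others in the source may bear on it.

Compound 1, `CCCC(=O)Nc1ncc(-c2cccc(Cl)c2)c(-c2ccccc2)n1`, reaches the limit > 80% in an assay on CHO cells for displacement of a labelled ligand from adenosine receptor A1 (Homo sapiens), read by scintillation counting, with a stated time of 1 h, tested at 1 uM; on this read-out lower numbers stand for less inhibition and higher numbers for more inhibition at the one concentration tested (going by the name of the read-out).
Compound 2, `Clc1cccc(-c2cnc(Nc3ccccc3)nc2-c2ccccc2)c1`, gives 34% in this assay.
Compound 3, `CNc1ncc(-c2cccc(Cl)c2)c(-c2ccccc2)n1`, gives 75% in this assay.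

Among the two plain numbers, compound 3 stands highest, and compound 2 sits far beneath it. Compound 1 reports only a limit, so it gives a floor rather than a number, as the entry the limit of > 80% in this assay, at which 1 of the 3 values shown sits, states. Compound 4, `Clc1cccc(-c2cnc(NC3CCCCC3)nc2-c2ccccc2)c1`, has not yet been measured. Its change from compound 3 is cyclohexyl in place of methyl on a nitrogen on an aromatic ring.

Among the compounds with values here, two measured steps touch the same nitrogen. The step of a number 41 percentage points higher from compound 2 to compound 3 (beyond the scatter) shows that exchanging a phenyl for a methyl there raised inhibition strongly. The step of a number at least 5 percentage points lower from compound 1 to compound 3 (that floor lies within the scatter) shows that going from propylcarbonyl to methyl changed little. A cyclohexyl is a bulky ring like phenyl, though not aromatic, so a drop from compound 3 is the more likely direction, yet its size is uncertain. The step from compound 3 to compound 4 is therefore expected to be a number 20 percentage points lower from compound 3 to compound 4 (beyond the scatter). Compound 4 is estimated to give 55% in this assay, with a range from 25% to 82%.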

Compound 4, a percentage reported as inhibition, at one concentration (the size of the read-out at that concentration, not a potency): 58%
Compound 4: the middle estimate sits 3 percentage points below what was measured; the measured number falls inside the stated range.
By their numbers in this assay, from the lowest: compound 2; then compound 4; then compound 3. At a limit, above all of these: compound 1.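

Cyclohexyl is the first non-aromatic ring seen on this nitrogen on an aromatic ring, and in this assay it falls in the middle of the series, with a number 17 percentage points lower from compound 3 to compound 4 (beyond the scatter) and with a number 24 percentage points higher from compound 2 to compound 4 (beyond the scatter) at this same position. Among these compounds, then, both rings on this nitrogen sit under methyl, but the two rings are not equivalent, and cyclohexyl keeps clearly more inhibition than phenyl. Compound 1 has a limit rather than a number, yet the comparison still reads a number at least 22 percentage points lower from compound 1 to compound 4 (beyond the scatter) for this change.

Going by these compounds, how a smaller ring such as cyclopropyl, an open chain such as ethyl, or a cyclohexyl carrying a hydroxyl group would fare at this nitrogen remains open. The data shown give no explanation for the gap between the two rings.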